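The compounds below may be only part of what the source reports. "The series", "measured", "known", "first", "only" and "open" are said of these compounds alone.

Measured so far in an assay on HEK293 cells for positive allosteric modulation of metabotropic glutamate receptor 2 (Rattus norvegicus), read by thallium flux, with a stated time of 2.5 min; a lower number here means a smaller maximal response, a higher number a larger maximal response:
compound 1, `Cc1c(OCCCCOc2ccc(C(=O)O)cc2)ccc(C(=O)CC2CCCC2)c1O`, 82.6%
compound 2, `Cc1c(OCCCCOc2ccc(C(=O)O)cc2)ccc(C(=O)CC2CCCC2)c1C`, 16.2%

For the measured compounds named here, compound 1 holds the higher of the two numbers; the only measured step, a number 66.4 percentage points lower from compound 1 to compound 2 (beyond the scatter), concerns the hydroxy on the shared core and is large.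

Compound 3, `Cc1c(OCCCCOc2ccc(C(=O)O)c(Cl)c2)ccc(C(=O)CC2CCCC2)c1O`, differs from compound 1 by chloro in place of hydrogen on an aromatic carbon. The measured step bears on a different part of the molecule, so nothing measured speaks to this change. The expectation is therefore no step beyond the scatter, a number 4.6 percentage points lower from compound 1 to compound 3 (within the scatter). In this assay compound 3 is estimated at 78%, range 50% to 100%.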

Compound 3, largest response reached (reported as percent of maximum), in percent of the reference or control that the assay uses: 80.8%
Beside the measured number, compound 3's estimate is 2.8 percentage points below it; the range from low to high includes it.
By their numbers in this assay, from the lowest: compound 2; then compounds 3 and 1 (each within the scatter of the next).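

In this assay, chloro in place of hydrogen on the aromatic carbon ortho to the carboxy group gives a number 1.8 percentage points lower from compound 1 to compound 3 (within the scatter), so the 4-carboxyphenyl end accepts this single added atom without a step beyond the scatter. This contrasts with the swap of hydroxy for methyl on the shared core, which gives a number 66.4 percentage points lower from compound 1 to compound 2 (beyond the scatter). Nothing at hand bears on the reason for this result.

Still open, from the compounds shown here alone, is whether fluoro, methoxy or an amine on this carbon would read the same. Also open, going by these compounds, is whether chloro would leave the number unchanged on the core of compound 2.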